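Adding a cyclopentenyl to an acetamide on a bridged diamine

The compounds below may be only part of what the source reports. "The series", "measured", "known", "first", "only" and "open" are said of these compounds alone.

Measured so far:
compound 1, `O=C(C1CC1)N1CC2CC1CN2`: 2800 nM
compound 2, `CC(=O)N1CC2CC(C1)N2`: 150 nM
compound 3, `O=C(C1CC=CC1)N1CC2CC(C1)N2`: 51 nM

In an assay on SH-EP1 cells for displacement of a labelled ligand from Neuronal acetylcholine receptor; alpha4/beta2 (Homo sapiens), read by scintillation counting (on this read-out lower numbers stand for stronger inhibition and higher numbers for weaker inhibition), compound 2 gives the second highest of the three numbers. Its nearest neighbour is compound 3, whose lower value lies beyond the scatter, while compound 1 stands furthest away with a much higher value. Compound 4, `O=C(CC1C=CCC1)N1CC2CC(C1)N2`, has not yet been measured. It differs from compound 2 by cyclopent-2-en-1-yl in place of hydrogen on a saturated chain carbon bound to a carbonyl carbon. Compound 3 carries a related five-membered ring directly on the carbonyl and gives 51 nM, so a lower number than compound 2 seems likely for compound 4. The expected step from compound 2 to compound 4 is a moderate drop, a 2.1-fold lower number from compound 2 to compound 4 (0.33 log units; beyond the scatter), beyond the scatter. Compound 4 is therefore estimated at 70 nM, within 20 nM to 250 nM.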

Compound 4, inhibition constant: 53 nM
Estimate against measurement, compound 4: 1.3-fold (0.12 log units) above; the range from low to high includes it.
By their numbers in this assay, from the lowest: compounds 3 and 4 (each within the scatter of the next); then compound 2; then compound 1.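

In this assay the swap of hydrogen for cyclopent-2-en-1-yl on a saturated chain carbon bound to a carbonyl carbon gives a 2.8-fold lower number from compound 2 to compound 4 (0.45 log units; beyond the scatter) as a modest step. Among these compounds, this is the first comparison in the set that changes only one place, and it shows that this carbon can carry the added ring without the number rising. Nothing measured here explains the drop.

Going by these compounds, whether a saturated cyclopentyl ring, a phenyl ring or a longer chain on this carbon would lower the number further remains open. So does the outcome with an amine there.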